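This account rests on a few compounds, and the source may have more. Where it says the series, first, only, none or still open, it means among the compounds named here.

Compound 1 `CN(C)c1ccc(/C=C(\C(=O)c2ccc(C(=O)O)cc2)S(=O)(=O)Cc2ccc(Cl)cc2)cc1` is known in a functional assay on DU-145 cells (Homo sapiens) for inhibition, read by trypan blue exclusion, with a stated time of 96 h (on this read-out lower numbers stand for stronger inhibition of growth and higher numbers for weaker inhibition of growth), only as a limit: in this assay compound 1 gives > 100000 nM, a limit of the assay and not a number (the limit of > 100000 nM in this assay, at which 1 of the 2 values shown sits). Compound 2 `COc1ccc(/C=C(/Sc2ccc(Br)cc2)C(=O)c2ccc(Br)cc2)c(F)c1` gives 20000 nM in this assay. Compound 3 `CN(C)c1ccc(/C=C(/SCc2ccc(F)cc2)C(=O)c2ccc(C(=O)O)cc2)cc1` has not been measured; it differs from compound 1 by (4-fluorobenzyl)sulfanyl in place of (4-chlorobenzyl)sulfonyl on a double-bonded chain carbon bound to a carbonyl carbon and a double-bonded chain carbon. Within the data shown here, no measured step between compounds is available, so the expectation rests on the two values shown. The step of an at least 2.5-fold lower number from compound 1 to compound 3 (0.39 log units; beyond the scatter) is expected to run toward stronger inhibition, beyond the usual scatter. Compound 3 is estimated at 40000 nM in this assay, within a range from 10000 nM to 150000 nM.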

Compound 3, concentration for 50% growth inhibition: 10000 nM
For compound 3 the middle estimate is 4.0-fold (0.60 log units) above the measured one; the range from low to high includes it.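

Among these compounds, this is the first step that can be read at this position: on a double-bonded chain carbon bound to a carbonyl carbon and a double-bonded chain carbon, (4-fluorobenzyl)sulfanyl in place of (4-chlorobenzyl)sulfonyl gives an at least 10-fold lower number from compound 1 to compound 3 (1.00 log units; beyond the scatter) in this assay. The position therefore responds to a change of this group while the rest of the core of compound 1 stays the same. The size of the step has only a lower bound, since one end is a limit and not a number: the limit of > 100000 nM in this assay, at which 1 of the 3 values shown sits.

The sulfur and the halogen change together, so the step cannot be divided between them; a (4-chlorobenzyl)sulfanyl group would separate the two. Going by these compounds, how an amine or a longer chain at this position would read remains open.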